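Replacing a Methyl Ketone with an Aryl Ketone

The source may hold more compounds than are shown below. What is called first, only, known or untested is meant among the compounds shown, and "the series" means these compounds.

Compound 1, `COc1cc(-c2cc(/C=C/C(C)=O)[nH]n2)cc(OC)c1OC`, carries a methyl ketone on a chain attached to the shared core. In a functional assay on MDA-MB-231 cells (Homo sapiens) for inhibition, read by MTT assay, with a stated time of 48 h (on this read-out lower numbers stand for stronger inhibition and higher numbers for weaker inhibition), compound 1 gives 27300 nM, the highest of the three numbers measured, which means the weakest inhibition among them. Compound 2, `COc1cc2c(cc1OC)C(=O)/C(=C/c1cc(-c3cc(OC)c(OC)c(OC)c3)n[nH]1)C2`, gives 2500 nM in this assay, and compound 3, `COc1ccc(-c2cc(/C=C/C(=O)c3cc(OC)c(OC)c(OC)c3)[nH]n2)cc1`, gives 2400 nM; each of these stands well below compound 1, a gap beyond the usual scatter, while the two of them lie within the scatter of each other, so no order between compound 2 and compound 3 can be read.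

Compound 4, `COc1ccc(C(=O)/C=C/c2cc(-c3cc(OC)c(OC)c(OC)c3)n[nH]2)cc1`, differs from compound 1 in one place: 4-methoxyphenyl in place of methyl on a carbonyl carbon. The chain and the trimethoxyphenyl-bearing core stay the same. Compound 3 also carries an aromatic ring on its carbonyl carbon rather than a methyl, and its value of 2400 nM sits far below compound 1, which suggests that a larger group at this position goes along with stronger inhibition. On this basis the step from compound 1 to compound 4 is expected to be a clear drop, a 7.8-fold lower number from compound 1 to compound 4 (0.89 log units; beyond the scatter), beyond the scatter. Compound 4 is therefore estimated at 3500 nM in this assay, with a likely range from 1200 nM to 10000 nM.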

Compound 4, half-maximal inhibitory concentration: 950 nM
Compound 4: middle estimate off by 3.7-fold (0.57 log units), on the high side; the measured number lies below the stated range.
By their numbers in this assay, from the lowest: compound 4; then compounds 3 and 2 (each within the scatter of the next); then compound 1.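

Putting 4-methoxyphenyl in place of methyl on a carbonyl carbon gives a 29-fold lower number from compound 1 to compound 4 (1.46 log units; beyond the scatter) in this assay and so a large gain in inhibition, while everything else in the molecule stays the same. Compound 1 and compound 4 form the one pair shown that differs in a single place, so this gain can be tied to this change alone, which the earlier values could not do. The carbonyl carbon therefore accepts far more than a methyl, and here the much larger group with its six-membered aromatic ring goes with stronger, not weaker, inhibition.

From the compounds shown here alone, what remains open is whether the gain needs the aromatic ring itself or its methoxy group, a question that a plain phenyl or a 4-fluorophenyl on the same carbonyl carbon would help to settle. Nothing in the data shown explains why this change has so large an effect.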